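Furan-2-yl in place of 1-benzofuran-2-yl on the shared core

The source may report more compounds than this note shows. Statements on the series, on what has been measured and on what is new or still open speak of the compounds shown alone.

Compound 1 `COc1ncnc2c1c(I)cn2[C@@H]1O[C@H](CO)[C@@H](O)[C@H]1O` bears iodo on the shared core. In a functional assay on HepG2 cells (Homo sapiens) for antiproliferative activity, read by XTT assay, with a stated time of 72 h (a lower number here means a stronger inhibitor, a higher number a weaker inhibitor), compound 1 gives only a limit of > 20000 nM. Compound 2 `COc1ncnc2c1c(-c1cc3ccccc3o1)cn2[C@@H]1O[C@H](CO)[C@@H](O)[C@H]1O` likewise gives only a limit of > 20000 nM in this assay. The step that the two limits leave unreadable from compound 1 to compound 2 is therefore unreadable, and the limit of > 20000 nM in this assay, at which 2 of the 2 values shown sit, is where both values sit. Compound 3 `COc1ncnc2c1c(-c1ccco1)cn2[C@@H]1O[C@H](CO)[C@@H](O)[C@H]1O` differs from compound 2 by furan-2-yl in place of 1-benzofuran-2-yl on an aromatic carbon. For the measured compounds named here, no measured step gives a readable size, so no shift beyond the scatter is expected in this assay. Compound 3 is estimated at 20000 nM, within 6000 nM to 60000 nM. That estimate means a step of a number no higher from compound 2 to compound 3 (the limit leaves the size open), most likely reported again as a limit.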

Compound 3, half-maximal inhibitory concentration: 300 nM
Compound 3: the middle estimate sits 67-fold (1.82 log units) above what was measured; measured number outside the range, below it.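

In this assay, this position now shows a readable response to its substituent: furan-2-yl in place of 1-benzofuran-2-yl gives an at least 66-fold lower number from compound 2 to compound 3 (1.82 log units; beyond the scatter), and furan-2-yl in place of iodo gives an at least 66-fold lower number from compound 1 to compound 3 (1.82 log units; beyond the scatter). The step between compound 1 and compound 2 cannot be read, and compound 3 alone stands clear of the limit: the limit of > 20000 nM in this assay, at which 2 of the 3 values shown sit.

The compounds shown leave open whether another five-membered aromatic ring, such as thiophen-2-yl, would keep this gain. They also leave open how an amine or a short alkyl chain would fare at this position.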